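The source may report more compounds than this note shows. Statements on the series, on what has been measured and on what is new or still open speak of the compounds shown alone.

Working notes. In a functional assay on DU-145 cells (Homo sapiens) for inhibition, read by trypan blue exclusion, with a stated time of 96 h (on this read-out lower numbers stand for stronger inhibition of growth and higher numbers for weaker inhibition of growth), compound 1 (`O=C(O)c1ccc(C(=O)/C(=C\c2ccc(Br)cc2)SCc2ccc(F)cc2)cc1`) gives > 100000 nM. That value is a limit and not a number: the limit of > 100000 nM in this assay, at which 1 of the 3 values shown sits. Compound 2 (`O=C(O)c1ccc(C(=O)/C(=C\c2ccc(Br)c([N+](=O)[O-])c2)SCc2ccc(F)cc2)cc1`) gives 1000 nM, and compound 3 (`CN(C)c1ccc(/C=C(/SCc2ccc(F)cc2)C(=O)c2ccc(C(=O)O)cc2)cc1`) gives 10000 nM. Compound 4 (`O=C(/C(=C\c1ccc(Br)cc1)SCc1ccc(F)cc1)c1ccc(Br)cc1`) departs from compound 1 as follows: bromo in place of carboxy on an aromatic carbon, para to a large group. Going by the values given here, no measured compound lacks the carboxy. The steps of an at least 100-fold lower number from compound 1 to compound 2 (2.00 log units; beyond the scatter) and an at least 10-fold lower number from compound 1 to compound 3 (1.00 log units; beyond the scatter) were both made elsewhere on the core, so they show that this series can move but give no size or direction for this change. No step beyond the scatter is therefore expected in this assay. The estimated step is an at least 1.6-fold lower number from compound 1 to compound 4 (0.22 log units; that floor lies within the scatter). For compound 4 the expected value is 60000 nM, with an estimated range of 10000 nM to 100000 nM.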

Compound 4, concentration for 50% growth inhibition: 25000 nM
The estimate for compound 4 lay 2.4-fold (0.38 log units) above the measured number, and the stated range covers the measured number.
By their numbers in this assay, from the lowest: compound 2; then compound 3; then compound 4. At a limit, above all of these: compound 1.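

Going by these compounds alone, removing the carboxy does not cost the growth inhibition in this assay, and this is the first reading at this place, on an aromatic carbon para to a large group. Bromo in place of carboxy gives an at least 4.0-fold lower number from compound 1 to compound 4 (0.60 log units; beyond the scatter). That step fixes a direction and a floor, not a size, with compound 1 standing at a limit: the limit of > 100000 nM in this assay, at which 1 of the 4 values shown sits.

Still open, as far as these compounds go, is whether an amide or a methyl ester at this place would read like the carboxy or like the bromo. From the compounds shown here alone, whether the same change would carry over to compound 2 also remains open.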